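The compounds below may be only part of what the source reports. "The series", "measured", "known", "first", "only" and "open" are said of these compounds alone.

Measured compounds and their values:
compound 1 `Cc1ccc(Nc2nc(C(F)(F)F)ccc2CNC(=O)C(C)c2ccc(NS(C)(=O)=O)c(F)c2)cc1C` with 1160 nM
compound 2 `Cc1ccc(Cl)cc1Nc1nc(C(F)(F)F)ccc1CNC(=O)C(C)c1ccc(NS(C)(=O)=O)c(F)c1` with 140 nM
compound 3 `CC(C(=O)NCc1ccc(C(F)(F)F)nc1NCc1ccc(Cl)cc1)c1ccc(NS(C)(=O)=O)c(F)c1` with 414 nM

All three share one core and differ only in the group carried on a nitrogen attached to that core. In a functional assay on CHO-K1 cells for antagonist activity at transient receptor potential cation channel subfamily V member 1 (Homo sapiens), read by FLIPR (on this read-out lower numbers stand for stronger inhibition and higher numbers for weaker inhibition), compound 3 gives 414 nM, the second highest of the three numbers: compound 1 sits above it, a 2.8-fold lower number from compound 1 to compound 3 (0.45 log units; beyond the scatter), and compound 2 sits below it, a 3.0-fold higher number from compound 2 to compound 3 (0.47 log units; beyond the scatter). The largest step among the measured compounds is an 8.3-fold lower number from compound 1 to compound 2 (0.92 log units; beyond the scatter).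

Compound 4 `CCCN(CCC)c1nc(C(F)(F)F)ccc1CNC(=O)C(C)c1ccc(NS(C)(=O)=O)c(F)c1` has not yet been measured. Its difference from compound 3 is dipropylamino in place of (4-chlorobenzyl)amino on an aromatic carbon. Among the compounds with values here, every measured step so far swaps one ring-bearing group for another ring-bearing group on that nitrogen, and those swaps moved the number by modest amounts in both directions. Within the data shown here, the change to compound 4 is of another kind: the group that enters has no ring and no hydrogen-bond donor, and no measured pair shows what such a change does. Among the measured compounds shown here, with no direct precedent, the expectation for compound 4 is a weaker result than compound 3, a step of a 7.2-fold higher number from compound 3 to compound 4 (0.86 log units; beyond the scatter) in this assay, held with wide uncertainty. Compound 4 is therefore estimated at 3000 nM, within a range from 800 nM to 12000 nM.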

Compound 4, half-maximal inhibitory concentration: 14.7 nM
Beside the measured number, compound 4's estimate is 200-fold (2.31 log units) above it; measured number below the stated range.
By their numbers in this assay, from the lowest: compound 4; then compound 2; then compound 3; then compound 1.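

In this assay, placing dipropylamino on the aromatic carbon next to the ring nitrogen gives the lowest number of the four compounds, and each comparison is beyond the scatter: (a 28-fold lower number from compound 3 to compound 4 (1.45 log units; beyond the scatter)) against the benzyl group, and (a 9.5-fold lower number from compound 2 to compound 4 (0.98 log units; beyond the scatter)) and (a 79-fold lower number from compound 1 to compound 4 (1.90 log units; beyond the scatter)) against the two substituted phenyl groups. Within the data shown here, the earlier compounds showed only that swapping one ring-bearing group for another moves the number, whereas compound 4 shows that neither a ring nor a hydrogen-bond donor on this nitrogen is needed for strong inhibition within this set, since the group that enters has no ring and 0 hydrogen-bond donors. Among these compounds, no measurement here explains why this change lowers the number so far.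

Because the ring and the amine hydrogen leave together in every comparison with compound 4, these compounds cannot separate the effect of losing one from that of losing the other; propylamino, with its single chain and amine hydrogen, and piperidine, a ring with no such hydrogen, would pull the two apart. Among the compounds shown here, how chain length counts also stays open, as dipropylamino is the only group of its type here, with nothing to set beside it such as diethylamino or dibutylamino.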